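Replacing the nitro group of compound 3

The compounds below may be only part of what the source reports. "The series", "measured", "known", "first", "only" and "open" are said of these compounds alone.

Values in an ADME assay on J774.A1 cells (Mus musculus) for cytotoxicity, read by MTT assay, with a stated time of 48 h (on this read-out higher numbers stand for lower toxicity in this test and lower numbers for higher toxicity in this test), are as follows
compound 1 `COc1ccc(/C=C(\C)C(=O)/C=C/c2ccc(N(C)C)cc2)cc1` gives 36200 nM
compound 2 `C/C(=C\c1ccc([N+](=O)[O-])cc1)C(=O)/C=C/c1ccc(N(C)C)cc1` gives 24700 nM
compound 3 `C/C(=C\c1ccc(N(C)C)cc1)C(=O)/C=C/c1ccc([N+](=O)[O-])cc1` gives 967000 nM
compound 4 `C/C(=C\c1ccc(N(C)C)cc1)C(=O)/C=C/c1ccc(N(C)C)cc1` has not yet been measured

Compound 3 has the highest number of the three measured compounds, beyond the scatter from both compound 1 and compound 2. Compound 4 differs from it in one place, (dimethylamino in place of nitro on an aromatic carbon), with the dimethylamino in place of nitro on an aromatic carbon. For the measured compounds named here, no measured step covers this change directly. The only one available, a 1.5-fold lower number from compound 1 to compound 2 (0.17 log units; within the scatter), concerns a different ring and stays within the scatter. It does show that two compounds with dimethylamino on the ring where compound 4 gains it lie close together, compound 1 at 36200 nM and compound 2 at 24700 nM in the same test. Compound 4 is therefore expected to fall towards them, a large step to a lower number, although three compounds are thin support and its other ring differs from both. The expected step is a 16-fold lower number from compound 3 to compound 4 (1.21 log units; beyond the scatter) by this estimate. In this assay the estimated value for compound 4 is 60000 nM with an expected range from 18000 nM to 300000 nM as its limits.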

Compound 4, half-maximal cytotoxic concentration: 10000 nM
Estimate against measurement, compound 4: 6.0-fold (0.78 log units) above, and the stated range ends above it.
By their numbers in this assay, from the lowest: compound 4; then compounds 2 and 1 (each within the scatter of the next); then compound 3.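

In this assay, dimethylamino in place of nitro on the ring where compound 3 carries its nitro group gives a 97-fold lower number from compound 3 to compound 4 (1.99 log units; beyond the scatter), so this position can shift the number strongly, which the earlier step on the other ring, within the scatter, gave no sign of. The same exchange on the other ring gives only a 2.5-fold lower number from compound 2 to compound 4 (0.39 log units; beyond the scatter), and dimethylamino in place of methoxy there gives a 3.6-fold lower number from compound 1 to compound 4 (0.56 log units; beyond the scatter), both modest but beyond the scatter, so that ring also has a measurable effect once both compounds carry dimethylamino on the first ring. The size of the nitro exchange thus depends on which ring carries the nitro group, with the high number of compound 3 standing apart from compound 2, its counterpart with the nitro group on the other ring.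

Nothing shown accounts for this difference between the two rings. The compounds leave open whether the low number of compound 4 is specific to dimethylamino or would also appear with a primary amine, a hydroxyl or a methoxy on that aromatic carbon.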